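Benzyl amide on an inactive benzofuran scaffold

A few compounds are considered here, and "the series" means these few. Any claim that something is new, unique, unknown or untested is made for them only; others in the source may bear on it.

Of the compounds shown here, three sharing one core have been tested in a functional assay on A549 cells (Homo sapiens) for cytotoxicity, read by MTT assay; a higher number here means a weaker inhibitor, a lower number a stronger inhibitor. Compound 1 `CCOC(=O)c1oc2cc(OC)cc(OC)c2c1C` gives "not active" (no number reported). Compound 2 `CCOC(=O)c1oc2c(C(N)=O)c(OC)cc(OC)c2c1C`, which carries an added primary amide on the core, gives "not active" (no number reported). Compound 3 `CCCNC(=O)c1oc2c(C(N)=O)c(OC)cc(OC)c2c1C`, with a propyl amide in place of the ethyl ester, gives > 93600 nM in this assay, and this figure is a limit of the measurement rather than a number. Compound 3 therefore stands at the weak end of what has been seen, and it is the only entry with any figure at all: the limit of > 93600 nM in this assay, at which 1 of the 3 values shown sits.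

The next compound, compound 4 `COc1cc(OC)c2c(C)c(C(=O)NCc3ccccc3)oc2c1C(N)=O`, differs from compound 3 in one place: phenyl in place of ethyl on a saturated chain carbon bound to an amide-type nitrogen. Going by the values given here, no measured pair shows what this change does on this core. With compound 3 sitting at a limit, the change from a step that the limit leaves unreadable from compound 3 to compound 4 is expected to stay within the scatter, with no clear gain. Compound 4 is expected to give 100000 nM in this assay, with a range from 30000 nM to 300000 nM.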

Compound 4, half-maximal inhibitory concentration: 54800 nM
For compound 4 the middle estimate is 1.8-fold (0.26 log units) above the measured one; the measured number falls inside the stated range.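

Replacing propyl with benzyl on the amide nitrogen gives the shared core a real reading: in this assay compound 4 gives 54800 nM, the only plain number among the compounds shown. The comparison reads as an at least 1.7-fold lower number from compound 3 to compound 4 (0.23 log units; that floor lies within the scatter), so it does not establish a gain from the phenyl group. The true size of the step cannot be read because compound 3 has only a limit: the limit of > 93600 nM in this assay, at which 1 of the 4 values shown sits.

Going by these compounds, whether the aromatic ring itself matters remains open, and a cyclohexyl group in place of the phenyl, or a longer chain such as phenylethyl, would help to separate ring from chain length. Also open, on these data alone, is what an amine or a carboxylic acid on this chain would do in this assay.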